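Swapping Fluoro for Phenyl in Compound 2

This account rests on a few compounds, and the source may have more. Where it says the series, first, only, none or still open, it means among the compounds named here.

Three compounds share one core. In a functional assay on MDA-MB-231 cells (Homo sapiens) for cytotoxicity, read by MTT assay, with a stated time of 48 h (on this read-out higher numbers stand for weaker inhibition and lower numbers for stronger inhibition), compound 1 `COc1cc(-n2c(-c3ccc(Br)cc3)csc2=S)cc(OC)c1OC` gives 58 ug/mL, compound 2 `COc1cc(-n2c(-c3ccc(F)cc3)csc2=S)cc(OC)c1OC` gives 19.5 ug/mL, and compound 3 `COc1cc(-n2c(-c3ccc(Cl)cc3Cl)csc2=S)cc(OC)c1OC` gives 49 ug/mL. Compound 2 therefore holds the lowest number of the three, set apart from both neighbours by steps beyond the scatter. Compound 4 `COc1cc(-n2c(-c3ccc(-c4ccccc4)cc3)csc2=S)cc(OC)c1OC` differs from compound 2 by phenyl in place of fluoro on an aromatic carbon. Going by the values given here, two measured steps bear on this: a 3.0-fold lower number from compound 1 to compound 2 (0.47 log units; beyond the scatter) and a 2.5-fold higher number from compound 2 to compound 3 (0.40 log units; beyond the scatter), each showing that the smaller fluoro gave the lower number and a larger substituent a higher one. A modest rise in this assay is therefore expected for compound 4, a 2.3-fold higher number from compound 2 to compound 4 (0.36 log units; beyond the scatter). Compound 4 is estimated at 45 ug/mL, with a range from 20 ug/mL to 100 ug/mL.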

Compound 4, half-maximal inhibitory concentration: > 100 ug/mL
Compound 4 was reported as a limit; the forecaster's own chance of this, stated with the estimate: 10%; at least 2.2-fold (0.34 log units) between middle value and limit.
By their numbers in this assay, from the lowest: compound 2; then compounds 3 and 1 (each within the scatter of the next). At a limit, above all of these: compound 4.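

In this assay, phenyl in place of fluoro on an aromatic carbon, para to a large group, gives an at least 5.1-fold higher number from compound 2 to compound 4 (0.70 log units; beyond the scatter), so an aromatic ring at this position carries the number to the limit of the read-out, not merely a halogen change. Phenyl in place of bromo gives an at least 1.7-fold higher number from compound 1 to compound 4 (0.23 log units; that floor lies within the scatter), and that floor alone does not separate the two. Compound 4 stands at a limit, not at a number: the limit of > 100 ug/mL in this assay, at which 1 of the 4 values shown sits.

From the compounds shown here alone, how far past that limit compound 4 lies remains open. So does whether an amine or a hydroxyl group at this position would keep the number near that of compound 2.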